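Amine substituents on the shared core

The source may report more compounds than this note shows. Statements on the series, on what has been measured and on what is new or still open speak of the compounds shown alone.

Measured in a functional assay on MCF7 cells (Homo sapiens) for cytotoxicity, read by MTT assay, with a stated time of 72 h; a higher number here means a weaker inhibitor, a lower number a stronger inhibitor:
compound 1 `O=c1ccc2nc(-c3ccccc3)nn(-c3ccccc3)c-2c1`, 810 nM
compound 2 `Nc1cc2nc(-c3ccccc3)nn(-c3ccccc3)c-2cc1=O`, 950 nM
compound 3 `CCNc1cc2nc(-c3ccccc3)nn(-c3ccccc3)c-2cc1=O`, 1620 nM

Compound 3 has the highest of the three numbers, yet both a 2.0-fold higher number from compound 1 to compound 3 (0.30 log units; within the scatter) and a 1.7-fold higher number from compound 2 to compound 3 (0.23 log units; within the scatter) stay within the scatter, so no order among the three is established. Compound 4 `O=c1cc2n(-c3ccccc3)nc(-c3ccccc3)nc-2cc1N1CCCCC1` differs from compound 3 in one place: piperidin-1-yl in place of ethylamino on an aromatic carbon. Among the compounds with values here, the steps that bear on this are the two that enlarge the amine at the same carbon, a 1.7-fold higher number from compound 2 to compound 3 (0.23 log units; within the scatter) and a 2.0-fold higher number from compound 1 to compound 3 (0.30 log units; within the scatter); neither leaves the scatter. A further enlargement is therefore expected to give at most a small upward step, a 1.4-fold higher number from compound 3 to compound 4 (0.13 log units; within the scatter), in this assay. Compound 4 is estimated at 2200 nM, within 900 nM to 5500 nM.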

Compound 4, half-maximal inhibitory concentration: 1980 nM
Beside the measured number, compound 4's estimate is 1.1-fold (0.05 log units) above it; the measured number falls inside the stated range.
By their numbers in this assay, from the lowest: compounds 1, 2, 3 and 4 (each within the scatter of the next, the first and the last beyond it).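

In this assay, piperidin-1-yl replaces ethylamino with no hydrogen-bond donor left at this carbon, yet a 1.2-fold higher number from compound 3 to compound 4 (0.09 log units; within the scatter) stays within the scatter. Steps at this position now leave the scatter for the first time: a 2.1-fold higher number from compound 2 to compound 4 (0.32 log units; beyond the scatter) is modest, as is a 2.4-fold higher number from compound 1 to compound 4 (0.39 log units; beyond the scatter), so compound 4 separates from compound 1 and compound 2 but not from compound 3. No measurement in hand accounts for these steps.

Diethylamino at this carbon would help separate the loss of the amine hydrogen from the closing of the ring. On these data alone, whether morpholin-4-yl or pyrrolidin-1-yl follows piperidin-1-yl remains open.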